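Aryl amide variation and human liver microsomal clearance

This account rests on a few compounds, and the source may have more. Where it says the series, first, only, none or still open, it means among the compounds named here.

Measured compounds:
- compound 1, `Cc1ccc(NC(=O)[C@H]2CN(C)C[C@@H]2c2ccc(/C=C/C(=O)Nc3ccccc3N)cc2)cc1`: 15 mL/min/kg
- compound 2, `Cc1cc(NC(=O)[C@H]2CN(C)C[C@@H]2c2ccc(/C=C/C(=O)Nc3ccccc3N)cc2)ccc1F`: 15 mL/min/kg
- compound 3, `Cc1cc(NC(=O)[C@H]2CN(C)C[C@@H]2c2ccc(/C=C/C(=O)Nc3ccccc3N)cc2)ccc1Cl`: 15 mL/min/kg

In an in vitro ADME assay on microsomes from liver (Homo sapiens) for pharmacokinetics, read by LC-MS, with a stated time of 10 min, tested at 1 uM (on this read-out higher numbers stand for fast clearance and lower numbers for slow clearance), compound 1 gives 15 mL/min/kg, and it stands level with compounds 2 and 3 at the digits shown. The step of no change at the digits printed from compound 1 to compound 2 (within the scatter) and the step of no change at the digits printed from compound 1 to compound 3 (within the scatter) both fall within the scatter, as does the step of no change at the digits printed from compound 2 to compound 3 (within the scatter). Across these three compounds, changing the substituents on the aryl group attached to the amide-type nitrogen leaves the read-out where it is.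

Compound 4, `CN1C[C@H](C(=O)Nc2cccnc2)[C@@H](c2ccc(/C=C/C(=O)Nc3ccccc3N)cc2)C1`, has not yet been measured in this assay. It differs from compound 1 in one place: pyridin-3-yl in place of 4-methylphenyl on an amide-type nitrogen. Among the measured compounds shown here, none of the measured steps covers an exchange of this kind; the measured steps only vary substituents on a carbocyclic ring, so they speak only indirectly to compound 4. Given that every measured step was flat, compound 4 is expected to sit near compound 1, with the step of a 1.2-fold lower number from compound 1 to compound 4 (0.06 log units; within the scatter) expected to lie within the scatter. The estimate for compound 4 is 13 mL/min/kg, expected to fall between 6 mL/min/kg and 28 mL/min/kg.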

Compound 4, clearance: 10 mL/min/kg
Estimate against measurement, compound 4: 1.3-fold (0.11 log units) above; low and high end bracket the measured number.
By their numbers in this assay, from the lowest: compounds 4, 1, 2 and 3 (each within the scatter of the next).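

In this assay, pyridin-3-yl in place of 4-methylphenyl on the amide-type nitrogen gives a 1.5-fold lower number from compound 1 to compound 4 (0.18 log units; within the scatter), so the read-out holds when the aryl ring itself takes a hetero atom and not only when its substituents vary. Among the compounds shown here, the same exchange starting from the two other aryl groups gives a 1.5-fold lower number from compound 3 to compound 4 (0.18 log units; within the scatter) and a 1.5-fold lower number from compound 2 to compound 4 (0.18 log units; within the scatter), and the flat picture of the earlier compounds thus extends to this one heteroaromatic ring. Nothing available here accounts for this outcome.

The compounds shown leave open whether pyridin-2-yl, pyridin-4-yl, a pyrimidine ring or a saturated cyclohexyl group on the same nitrogen would stay level in this assay as well. They also give no reading for an aryl ring carrying an amine or a carboxylic acid.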